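This account rests on a few compounds, and the source may have more. Where it says the series, first, only, none or still open, it means among the compounds named here.

Of the compounds shown here, three have been measured in a functional assay on MDA-MB-231 cells (Homo sapiens) for inhibition, read by MTT assay; a lower number here means a stronger inhibitor of growth, a higher number a weaker inhibitor of growth. Compound 1 `CC1=C(/C=C/C(C)=C/C=C/C(C)=C\C(=O)NCc2ccc(O)cc2)C(C)(C)CC=C1c1cncnc1` gives 11500 nM, compound 2 `CC1=C(/C=C/C(C)=C/C=C/C(C)=C\C(=O)NCc2ccc(O)cc2)C(C)(C)CCC1n1ccnc1` gives 2230 nM, and compound 3 `CC1=C(/C=C/C(C)=C/C=C/C(C)=C\C(=O)Nc2ccccc2O)C(C)(C)CCC1n1ccnc1` gives 4670 nM. Compound 2 therefore has the lowest number of the three; its nearest neighbour is compound 3, with a 2.1-fold higher number from compound 2 to compound 3 (0.32 log units; beyond the scatter), while the numbers for compound 2 and compound 1 lie further apart. Compound 4 `CC1=C(/C=C/C(C)=C/C=C/C(C)=C\C(=O)NCc2ccccc2)C(C)(C)CCC1n1ccnc1` differs from compound 2 only by hydrogen in place of hydroxy on an aromatic carbon. Within the data shown here, no measured step removes a hydroxy group on its own; the one step available, from compound 2 to compound 3, altered the amide substituent more broadly and was modest. A small weakening beyond the scatter is therefore expected, a 1.6-fold higher number from compound 2 to compound 4 (0.21 log units; within the scatter), so compound 4 is estimated at 3600 nM, with a range from 1500 nM to 8500 nM.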

Compound 4, concentration for 50% growth inhibition: 5880 nM
The estimate for compound 4 lay 1.6-fold (0.21 log units) below the measured number, within the range that was stated.
By their numbers in this assay, from the lowest: compound 2; then compounds 3, 4 and 1 (each within the scatter of the next, the first and the last beyond it).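

Taken alone, losing the hydroxy group, as 4-hydroxybenzyl becomes benzyl, gives a 2.6-fold higher number from compound 2 to compound 4 (0.42 log units; beyond the scatter) in this assay, so this single group on the aromatic ring affects growth inhibition by itself. Benzyl in place of 2-hydroxyphenyl gives a 1.3-fold higher number from compound 3 to compound 4 (0.10 log units; within the scatter), so compound 3 and compound 4 cannot be told apart here. Nothing available explains why the hydroxy group matters. Going by these compounds, whether a methoxy group, an amine or a fluorine on that carbon would match compound 2 stays open, as does the effect of a longer chain in place of benzyl.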